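Replacing the acyl side chain on a thiazolidine amide core

A few compounds are considered here, and "the series" means these few. Any claim that something is new, unique, unknown or untested is made for them only; others in the source may bear on it.

Measured compounds:
Compound 1 `COc1ccccc1OCC1SCCN1C(=O)C[S+](C)[O-]`: 25 mg/kg
Compound 2 `C=CC(=O)N1CCSC1COc1ccccc1OC`: 74 mg/kg
Compound 3 `COc1ccccc1OCC1SCCN1C(=O)CC(=O)O`: 20 mg/kg

In a functional assay on the whole organism for inhibition, with Cavia porcellus as the target (a lower number here means that less compound is needed, a higher number that more compound is needed for the effect), compound 1 gives 25 mg/kg and stands second highest of the three numbers: its nearest neighbour is compound 3, whose step a 1.3-fold lower number from compound 1 to compound 3 (0.10 log units; within the scatter) lies within the scatter, and its furthest is compound 2, reached by a 3.0-fold higher number from compound 1 to compound 2 (0.47 log units; beyond the scatter).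

Compound 4 `CCOC(=O)C(C)(C)C(=O)N1CCSC1COc1ccccc1OC` has not yet been measured. Relative to compound 1 the change is a group of 8 heavy atoms (6 carbon, 2 oxygen; no ring) in place of a group of 4 heavy atoms (2 carbon, 1 oxygen, 1 sulfur; no ring), on a carbonyl carbon. Within the data shown here, two measured steps touch the same carbonyl carbon or the chain on it. The step of a 3.0-fold higher number from compound 1 to compound 2 (0.47 log units; beyond the scatter) shows that removing this group altogether in favour of vinyl costs a modest amount. The step of a 1.3-fold lower number from compound 1 to compound 3 (0.10 log units; within the scatter) shows that swapping the sulfur-bearing end of the chain for a carboxylic acid leaves the number essentially unchanged. Among the measured compounds shown here, no measured compound carries an ester or a branched chain on this carbonyl, so the direction is uncertain; a modest shift, more likely upward, is expected.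

Compound 4 is therefore estimated at 40 mg/kg, with a range from 15 mg/kg to 110 mg/kg, which means an expected step of a 1.6-fold higher number from compound 1 to compound 4 (0.20 log units; within the scatter).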

Compound 4, dose for half-maximal effect: 61 mg/kg
Beside the measured number, compound 4's estimate is 1.5-fold (0.18 log units) below it, and the stated range covers the measured number.
By their numbers in this assay, from the lowest: compounds 3 and 1 (each within the scatter of the next); then compounds 4 and 2 (each within the scatter of the next).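

In this assay the carbonyl carbon takes the much larger 1-(ethoxycarbonyl)-1-methylethyl group at a cost, shown by a 2.4-fold higher number from compound 1 to compound 4 (0.39 log units; beyond the scatter) and by a 3.1-fold higher number from compound 3 to compound 4 (0.48 log units; beyond the scatter), both beyond the scatter, while a 1.2-fold lower number from compound 2 to compound 4 (0.08 log units; within the scatter) stays within it. Compound 4 therefore groups with compound 2 rather than with compounds 1 and 3, and the number does not follow the size of the group in these four compounds: vinyl, the smallest group here, and 1-(ethoxycarbonyl)-1-methylethyl, the largest, give numbers within the scatter of each other. Nothing measured here accounts for this split into two pairs.

From the compounds shown here alone, compound 4 differs from compound 3 in both the ester and the two methyl branches, so the share of each in that step remains open; an unbranched ethoxycarbonylmethyl group or a 1-carboxy-1-methylethyl group on the same carbonyl carbon would separate them. Going by these compounds, it also remains open how a chain ending in an amine would fare at this position, since only neutral or acid-ended chains are represented.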